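A half-life estimate for compound 3

The compounds below may be only part of what the source reports. "The series", "measured", "known", "first", "only" and "open" are said of these compounds alone.

Compound 1 `CC(C)C(/C=C1\NC(=O)NC1=O)c1ccc(-c2ccc3cccc(F)c3c2)[nH]c1=O`: 1.46 h
Compound 2 `O=C1NC(=O)/C(=C/C2(c3ccc(-c4ccc5cccc(F)c5c4)[nH]c3=O)CCCC2)O1`: > 3 h

Going by the values given here, in an ADME assay on microsomes from liver (Rattus norvegicus) for metabolic stability (on this read-out higher numbers stand for a longer-lived compound and lower numbers for a shorter-lived compound), compound 1 gives 1.46 h, the only exact number so far. For compound 2, > 3 h is a limit of the assay and not a number. Compound 3 `CC(C)C(CC1NC(=O)NC1=O)c1ccc(-c2ccc3cccc(F)c3c2)[nH]c1=O` has not been measured. It differs from compound 1 in one place: a group of 8 heavy atoms (4 carbon, 2 nitrogen, 2 oxygen; one five-membered non-aromatic ring with 2 hetero atoms) in place of a group of 8 heavy atoms (4 carbon, 2 nitrogen, 2 oxygen; one five-membered non-aromatic ring with 2 hetero atoms), on a saturated chain carbon bound to an aromatic carbon and a saturated chain carbon. Among the compounds with values here, no measured pair shows this change, so no step beyond the usual scatter is expected in this assay, and no direction can be favoured. The estimated step of a 1.1-fold higher number from compound 1 to compound 3 (0.04 log units; within the scatter) stays within that scatter. Compound 3 is expected at 1.6 h, with an estimated range of 0.7 h to 3.2 h.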

Compound 3, half-life: 0.35 h
Beside the measured number, compound 3's estimate is 4.6-fold (0.66 log units) above it; measured number outside the range, below it.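

In this assay, the change to the (2,5-dioxoimidazolidin-4-yl)methyl group gives a 4.2-fold lower number from compound 1 to compound 3 (0.62 log units; beyond the scatter). The group that leaves and the one that enters have the same heavy atoms, but the entering group has 2 double bonds outside aromatic rings in place of 3. The half-life at this place can therefore shift with a change this small, although one pair cannot show why.

Going by these compounds, whether a carboxylic acid or an amine at this place would shorten the half-life as well stays open. Compound 2 offers only a limit of the assay, not a number: the limit of > 3 h in this assay, at which 1 of the 3 values shown sits.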